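Bombesin receptor subtype-3 agonists: swapping a saturated ring for phenyl

The source may report more compounds than this note shows. Statements on the series, on what has been measured and on what is new or still open speak of the compounds shown alone.

Measured compounds:
- compound 1, `O=C(O)c1ccccc1-c1ccc(CCc2ncc(C3CCCCC3)[nH]2)cc1`, 375 nM
- compound 2, `Cc1cccc(Cc2cnc(CCc3ccc(-c4ccccc4C(=O)O)cc3)[nH]2)c1`, 4310 nM

In an in vitro functional assay on cells for agonist activity at Bombesin receptor subtype-3 (Homo sapiens), read by luminescence and calcium flux (on this read-out lower numbers stand for an effect already at smaller amounts and higher numbers for an effect only at larger amounts of compound), compound 1 gives the lower of the two numbers; compound 2 sits an 11-fold higher number from compound 1 to compound 2 (1.06 log units; beyond the scatter) away. That single step shows what one change at this position on the five-membered ring can do: replacing cyclohexyl with 3-methylbenzyl raised the number sharply.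

Compound 3, `O=C(O)c1ccccc1-c1ccc(CCc2ncc(-c3ccccc3)[nH]2)cc1`, has not yet been tested in this assay. It differs from compound 1 by phenyl in place of cyclohexyl on an aromatic carbon. Among the measured compounds shown here, no measured pair shows exactly phenyl in place of cyclohexyl, so the only guide is the step from compound 1 to compound 2, where a different group at the same position cost an 11-fold higher number from compound 1 to compound 2 (1.06 log units; beyond the scatter). Phenyl is a smaller change than 3-methylbenzyl, so a milder shift in the same direction is expected, a 2.4-fold higher number from compound 1 to compound 3 (0.38 log units; beyond the scatter). Compound 3 is therefore estimated at 900 nM, with a range from 300 nM to 3000 nM.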

Compound 3, half-maximal effective concentration: 4950 nM
Compound 3: middle estimate off by 5.5-fold (0.74 log units), on the low side; the measured number lies above the stated range.
By their numbers in this assay, from the lowest: compound 1; then compounds 2 and 3 (each within the scatter of the next).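

In this assay the swap of cyclohexyl for phenyl gives a 13-fold higher number from compound 1 to compound 3 (1.12 log units; beyond the scatter) as a large step, even though the two groups have the same count of heavy atoms and differ in that one ring is aromatic and the other is not. So the loss seen with 3-methylbenzyl does not need a group with more atoms, and the comparison of the two aromatic groups gives a 1.1-fold higher number from compound 2 to compound 3 (0.06 log units; within the scatter) with no real difference between them. Of the three compounds, only compound 1, with its non-aromatic ring, stands apart, and nothing available here explains why.

The compounds shown do not tell whether a smaller saturated ring such as cyclopentyl, or an open chain such as n-butyl, would keep the lower number. They also leave open how an amine on the cyclohexyl ring would behave.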